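Swapping methyl for fluoro on a hydroxy-bearing ring

A few compounds are considered here, and "the series" means these few. Any claim that something is new, unique, unknown or untested is made for them only; others in the source may bear on it.

Measured in a functional assay on HL-60 cells (Homo sapiens) for cytotoxicity, read by luminescence and CellTiter-Glo, with a stated time of 3 days (a higher number here means a weaker inhibitor, a lower number a stronger inhibitor), so far:
Compound 1 `Cc1ccc(C(=O)Nc2ccc(C#N)cc2)c(O)c1` gives 2420 nM
Compound 2 `N#Cc1ccc(NC(=O)c2cc(C(F)(F)F)ccc2O)cc1` gives 3120 nM
Compound 3 `N#Cc1ccc(NC(=O)c2ccc3cccnc3c2O)c(Cl)c1` gives 910 nM

Compound 1 sits within the usual scatter of compound 2, so these two cannot be told apart. Compound 3 gives a lower number than compound 1, and that gap lies beyond the scatter.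

The next compound to be tested is compound 4 `N#Cc1ccc(NC(=O)c2ccc(F)cc2O)cc1`. It carries fluoro in place of methyl on an aromatic carbon, meta to a hydroxy group and para to a large group, and the count of that change reads (fluoro in place of methyl on an aromatic carbon).

For the measured compounds named here, no measured pair isolates this swap. The closest guide is compound 2 at 3120 nM in this assay, which carries a different group yet stays within the scatter of compound 1. Little change is therefore expected, with no step beyond the scatter. The estimated step of a 1.2-fold higher number from compound 1 to compound 4 (0.06 log units; within the scatter) is expected to stay within the scatter. Compound 4 is expected at 2800 nM in this assay, with an estimated range from 1200 nM to 6500 nM as its likely span.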

Compound 4, half-maximal inhibitory concentration: 1380 nM
The estimate for compound 4 lay 2.0-fold (0.31 log units) above the measured number, within the range that was stated.
By their numbers in this assay, from the lowest: compounds 3, 4, 1 and 2 (each within the scatter of the next, the first and the last beyond it).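

For the compounds shown here, compounds 1 and 4 are the first pair here that differ in one place only, so this swap can now be read directly. In this assay the step of a 1.8-fold lower number from compound 1 to compound 4 (0.24 log units; within the scatter) shows that fluoro in place of methyl on this aromatic carbon, meta to a hydroxy group and para to a large group, leaves the two compounds indistinguishable. This single pair therefore gives no sign that the choice between these two small groups matters at this place in the core of compound 1, and nothing available explains the result.

On these data alone, it remains open whether an amine or a carboxylic acid on this same carbon would shift the number beyond the scatter. It is also unknown whether the same swap would behave alike on the core of compound 3.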